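A few compounds are considered here, and "the series" means these few. Any claim that something is new, unique, unknown or untested is made for them only; others in the source may bear on it.

In an in vitro assay on CHO cells for displacement of a labelled ligand from Bombesin receptor subtype-3 (Homo sapiens), read by scintillation counting, with a stated time of 2 h (on this read-out higher numbers stand for weaker inhibition and lower numbers for stronger inhibition), the three measured compounds give the following numbers:

compound 1 `CCC(C)(C)Cc1c[nH]c(CCc2ccc(-c3cccc(C#N)n3)cc2)n1`: 140 nM
compound 2 `CCC(C)(C)Cc1c[nH]c(CCc2ccc(-c3ccc(F)cn3)cc2)n1`: 19 nM
compound 3 `CCC(C)(C)Cc1c[nH]c(CCc2ccc(-c3csnn3)cc2)n1`: 45 nM

Compound 3 stands second highest of the three numbers. Its neighbours are set by a 2.4-fold higher number from compound 2 to compound 3 (0.37 log units; beyond the scatter) on the one side and by a 3.1-fold lower number from compound 1 to compound 3 (0.49 log units; beyond the scatter) on the other, both beyond the scatter, both modest.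

Compound 4 `CCC(C)(C)Cc1c[nH]c(CCc2ccc(-c3cnsc3)cc2)n1` is the next member. Relative to compound 3 the change is 1,2-thiazol-4-yl in place of 1,2,3-thiadiazol-4-yl on an aromatic carbon. Every measured step in the series alters the same group in the same place, so all three bear on it: a 7.4-fold lower number from compound 1 to compound 2 (0.87 log units; beyond the scatter), a 3.1-fold lower number from compound 1 to compound 3 (0.49 log units; beyond the scatter) and a 2.4-fold higher number from compound 2 to compound 3 (0.37 log units; beyond the scatter). None exceeds a modest size, and the two five- and six-membered heteroaryl swaps seen so far move the number in either direction by comparable amounts. The step from compound 3 to compound 4 is a smaller change than any of those, so the expectation in this assay is a step near the scatter, with no firm direction. The estimate for compound 4 is 40 nM, range 15 nM to 110 nM, which corresponds to an expected step of a 1.1-fold lower number from compound 3 to compound 4 (0.05 log units; within the scatter).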

Compound 4, half-maximal inhibitory concentration: 10 nM
Compound 4: the middle estimate sits 4.0-fold (0.60 log units) above what was measured; the measured number lies below the stated range.
By their numbers in this assay, from the lowest: compounds 4 and 2 (each within the scatter of the next); then compound 3; then compound 1.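

Working from this assay, the aromatic carbon para to a large group responds to more than whole-ring replacement: 1,2-thiazol-4-yl and 1,2,3-thiadiazol-4-yl have the same ring size and heavy-atom count, with one ring nitrogen exchanged for carbon, yet the change gives a 4.5-fold lower number from compound 3 to compound 4 (0.65 log units; beyond the scatter). Set against the six-membered rings, the new group gives a 1.9-fold lower number from compound 2 to compound 4 (0.28 log units; within the scatter), so it cannot be ordered against 5-fluoropyridin-2-yl, while a 14-fold lower number from compound 1 to compound 4 (1.15 log units; beyond the scatter) is the first large step in the series and widens the spread at this position. Nothing at hand accounts for the size of any of these steps.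

Still open, on these data alone, is how much of the step from compound 3 to compound 4 follows the count of ring nitrogens and how much follows their placement, a question that thiophen-3-yl or 1,3-thiazol-5-yl at this position would help to settle. Also open is whether the position needs an aromatic ring at all, since every group shown is one, and a morpholine, a primary amine or a carboxylic acid here would test that.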